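Pyridazinone anilides: trifluoromethoxyphenyl for bromofluorophenyl

The compounds below may be only part of what the source reports. "The series", "measured", "known", "first", "only" and "open" are said of these compounds alone.

Three compounds of this series have been run in a functional assay on A549 cells (Homo sapiens) for cytotoxicity, read by MTT assay, with a stated time of 72 h; on this read-out lower numbers stand for stronger inhibition and higher numbers for weaker inhibition. Compound 1 `CNC(=O)c1cc(Oc2ccc(NC(=O)c3nn(-c4ccccc4OC(F)(F)F)c(=O)cc3C)cc2F)ccn1` reaches only the limit of the assay, > 40000 nM, so no number stands for it (the limit of > 40000 nM in this assay, at which 1 of the 3 values shown sits). Compound 2 `Cc1cc(=O)n(-c2ccccc2OC(F)(F)F)nc1C(=O)Nc1ccc(Oc2ncnc3ccsc23)cc1` gives 10100 nM in this assay. Compound 3 `Cc1cc(=O)n(-c2ccc(Br)cc2F)nc1C(=O)Nc1ccc(Oc2ncnc3ccsc23)c(F)c1` gives 2980 nM, the lowest of the two numbers, and its gap to compound 2 lies beyond the scatter. Compound 4 `Cc1cc(=O)n(-c2ccccc2OC(F)(F)F)nc1C(=O)Nc1ccc(Oc2ncnc3ccsc23)c(F)c1` has not been measured; it differs from compound 3 by 2-(trifluoromethoxy)phenyl in place of 4-bromo-2-fluorophenyl on an aromatic nitrogen. Since compound 2 also carries the 2-(trifluoromethoxy)phenyl group and gives 10100 nM, a weakening step from compound 3 to compound 4 is expected, a 2.0-fold higher number from compound 3 to compound 4 (0.30 log units; within the scatter), beyond the scatter. Compound 4 is therefore estimated at 6000 nM in this assay, with a range from 2500 nM to 15000 nM.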

Compound 4, half-maximal inhibitory concentration: 5720 nM
For compound 4 the middle estimate is 1.0-fold (0.02 log units) above the measured one; the measured number falls inside the stated range.
By their numbers in this assay, from the lowest: compounds 3, 4 and 2 (each within the scatter of the next, the first and the last beyond it). At a limit, above all of these: compound 1.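

In this assay, 2-(trifluoromethoxy)phenyl in place of 4-bromo-2-fluorophenyl on the aromatic nitrogen gives a 1.9-fold higher number from compound 3 to compound 4 (0.28 log units; within the scatter), so the two aryl groups cannot be told apart at this position. Fluoro in place of hydrogen on an aromatic carbon likewise gives a 1.8-fold lower number from compound 2 to compound 4 (0.25 log units; within the scatter). Within the data shown here, compound 1 stands at a limit of the assay, and the group on the oxygen on an aromatic ring is the only change here beyond the scatter: an at least 6.9-fold lower number from compound 1 to compound 4 (0.84 log units; beyond the scatter).

Open, from the compounds shown here alone, is how a non-aryl group, such as a methyl or a piperidine-bearing alkyl chain, would read on the aromatic nitrogen.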